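The compounds below may be only part of what the source reports. "The series", "measured", "known", "first", "only" and "open" are said of these compounds alone.

Measured compounds in a functional assay on HCT-116 cells (Homo sapiens) for cytotoxicity, read by MTT assay, with a stated time of 72 h; on this read-out lower numbers stand for stronger inhibition and higher numbers for weaker inhibition:

Compound 1 `COc1cc(Nc2nc3ccccc3nc2S(=O)(=O)c2ccc(C)cc2)cc(OC)c1` sits at the assay limit of > 50000 nM in this assay.
Compound 2 `COc1cc(Nc2nc3ccccc3nc2S(=O)(=O)c2ccc(C)cc2)cc(OC)c1OC` gives 10800 nM in this assay.
Compound 3 `O=S(=O)(c1ccc(Br)cc1)c1nc2ccccc2nc1Nc1ccc(C(F)(F)F)cc1` gives 2610 nM in this assay.

Of the two numbers in this assay, compound 2 has the higher one; the nearest value is that of compound 3, which is lower by a step beyond the scatter. Compound 3 differs from compound 2 in more than one place, so its value is noted only as it stands.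

For the measured compounds named here, the one measured step in this assay, an at least 4.6-fold lower number from compound 1 to compound 2 (0.66 log units; beyond the scatter), runs into the limit described by the limit of > 50000 nM in this assay, at which 1 of the 3 values shown sits, so its full size is not known. It changes a different position from the one at issue here.

Compound 4 `COc1cc(Nc2nc3ccccc3nc2S(=O)(=O)c2ccc(F)cc2)cc(OC)c1OC` differs from compound 2 by fluoro in place of methyl on an aromatic carbon. Going by the values given here, no measured step in this assay alters this sulfonyl-bearing ring alone, so nothing bears directly on the change. Among the compounds with values here, with no comparable step to point to, the expected change from compound 2 to compound 4 is a 1.1-fold lower number from compound 2 to compound 4 (0.03 log units; within the scatter), within the scatter. Compound 4 is therefore estimated at 10000 nM, with a range from 3500 nM to 30000 nM.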

Compound 4, half-maximal inhibitory concentration: 3110 nM
Compound 4: the middle estimate sits 3.2-fold (0.51 log units) above what was measured; the measured number lies below the stated range.
By their numbers in this assay, from the lowest: compounds 3 and 4 (each within the scatter of the next); then compound 2. At a limit, above all of these: compound 1.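

In this assay, for the compounds shown here, the group on the sulfonyl-bearing ring proves able to move the number on its own: with the rest of the structure held fixed, the exchange of 4-methylphenyl for 4-fluorophenyl gives a 3.5-fold lower number from compound 2 to compound 4 (0.54 log units; beyond the scatter) and so a step beyond the scatter at a position no earlier pair had touched. This makes it the second position in the series where a single change shifts the read-out, and the only one of the two where both ends of the step are measured numbers. Nothing shown gives a reason for this step.

Going by these compounds, whether the step reflects the arrival of fluoro or the departure of methyl stays open, as does how a nitrile, an amine or a carboxylic acid would read on this carbon. Also open, on these data alone, is whether the same exchange holds on the dimethoxy pattern of compound 1.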